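Swapping Trifluoromethyl for Phenyl on the Shared Core

The source may hold more compounds than are shown below. What is called first, only, known or untested is meant among the compounds shown, and "the series" means these compounds.

Measured compounds in an assay on HEK-293T cells for inhibition of diacylglycerol lipase-alpha (Homo sapiens), read by colorimetric assay; on this read-out lower numbers stand for stronger inhibition and higher numbers for weaker inhibition:
- compound 1, `O=C(CCCCCCc1ccccc1)c1ccc(-c2ccco2)nn1`: > 10000 nM
- compound 2, `O=C(CCCCCCc1ccccc1)c1nc(C(F)(F)F)co1`: 214 nM
- compound 3, `CC(=O)c1cnc(C(=O)CCCCCCc2ccccc2)o1`: > 10000 nM

Compound 1 gives only a limit of the assay, not a number. Compound 3 likewise sits at a limit and gives no number. Among the measured compounds shown here, compound 2 is therefore the only compound here with a measured number, and the limit of > 10000 nM in this assay, at which 2 of the 3 values shown sit, marks where the other two stand. For the measured compounds named here, no two measured compounds differ in a single place, so no measured step is available to guide a prediction.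

Compound 4, `O=C(CCCCCCc1ccccc1)c1nc(-c2ccccc2)co1`, has not yet been measured. It differs from compound 2 by phenyl in place of trifluoromethyl on an aromatic carbon. The five-membered aromatic ring with one nitrogen and one oxygen, and the long chain ending in a phenyl on the other side of the carbonyl, are kept unchanged.

Going by the values given here, with no measured step of this kind at hand, the direction of the change cannot be read from the data. Compound 4 is expected to be somewhat weaker than compound 2, an estimated step of a 3.7-fold higher number from compound 2 to compound 4 (0.57 log units; beyond the scatter) in this assay. The estimate for compound 4 is 800 nM, with a range from 150 nM to 5000 nM.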

Compound 4, half-maximal inhibitory concentration: 8710 nM
The estimate for compound 4 lay 11-fold (1.04 log units) below the measured number; the measured number lies above the stated range.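

Placing phenyl where trifluoromethyl stood gives a 41-fold higher number from compound 2 to compound 4 (1.61 log units; beyond the scatter) in this assay, and this is the first one-place comparison in the set. It shows that this aromatic carbon, next to the ring nitrogen, is not indifferent to what it carries: with the rest of the molecule unchanged, replacing trifluoromethyl with a group that brings an aromatic ring of its own comes with much weaker inhibition. Both ends of this step are real numbers, unlike compound 1 and compound 3, which each stand at a limit of the assay and not at a number: the limit of > 10000 nM in this assay, at which 2 of the 4 values shown sit.

On these data alone, a single step cannot separate the effect of losing trifluoromethyl from the effect of adding phenyl, so it remains open whether a methyl group or a chlorine atom at this carbon would stay close to compound 2. Also open, as far as these compounds go, is whether a phenyl ring carrying a fluorine atom, or a smaller ring, would recover any of the lost inhibition, and whether the same change would cost as much with a shorter chain on the other side of the carbonyl.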